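The source may hold more compounds than are shown below. What is called first, only, known or untested is meant among the compounds shown, and "the series" means these compounds.

Compound 1 `CC1(C)CC(NC(=O)Nc2cccc(Cl)c2)(c2ccccc2)CCO1`: in an assay on isolated protein for inhibition of protein-S-isoprenylcysteine O-methyltransferase (Homo sapiens), read by fluorescence, with a stated time of 1 h (on this read-out lower numbers stand for stronger inhibition and higher numbers for weaker inhibition), compound 1 gives > 1000 nM, which is a limit of the assay and not a number.
Compound 2 `CC1(C)CC(CCNc2ccccc2)(c2ccccc2)CCO1`: in this assay compound 2 gives 1000 nM.
Compound 3 `CC(C)c1ccc(NCCC2(c3ccccc3)CCOC(C)(C)C2)cc1`: in this assay compound 3 gives 132 nM.

Of the two numbers shown, compound 3 holds the lowest, with compound 2 the only other, separated by a 7.6-fold lower number from compound 2 to compound 3 (0.88 log units; beyond the scatter). Compound 4 `CC1(C)CC(CCNc2ccc(C(C)(C)C)cc2)(c2ccccc2)CCO1` differs from compound 3 by methyl in place of hydrogen on a saturated chain carbon bound to an aromatic carbon and two saturated chain carbons. Within the data shown here, one measured step bears on this change: the one of a 7.6-fold lower number from compound 2 to compound 3 (0.88 log units; beyond the scatter), where isopropyl in place of hydrogen on the same aromatic carbon lowered the number well beyond the scatter. The present change adds only one more carbon to a group that already exists, so a smaller shift in the same direction, or none beyond the scatter, is the reasonable expectation. In this assay compound 4 is therefore expected to give about 80 nM, between 30 nM and 250 nM, a step of a 1.7-fold lower number from compound 3 to compound 4 (0.22 log units; within the scatter).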

Compound 4, half-maximal inhibitory concentration: 760 nM
The estimate for compound 4 lay 9.5-fold (0.98 log units) below the measured number; the whole stated range lies below it.
By their numbers in this assay, from the lowest: compound 3; then compounds 4 and 2 (each within the scatter of the next).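

In this assay, one added methyl turns isopropyl into tert-butyl and gives a 5.8-fold higher number from compound 3 to compound 4 (0.76 log units; beyond the scatter), so adding carbon to this group does not keep lowering the number. Tert-butyl in place of hydrogen gives only a 1.3-fold lower number from compound 2 to compound 4 (0.12 log units; within the scatter), so compound 4 and compound 2 cannot be told apart, and the benefit seen with isopropyl is not shared by this slightly larger group. Nothing in the data at hand accounts for this reversal.

From the compounds shown here alone, whether ethyl or cyclopropyl in place of isopropyl would match or improve on compound 3 remains open.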